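The compounds below may be only part of what the source reports. "The series", "measured", "known", "first", "only" and "open" are said of these compounds alone.

Measured so far:
compound 1, `C[C@H](c1ccc(C(=O)NCCC(=O)O)cc1)N1C(=O)C(c2ccc(F)cc2)=N[C@]12CC[C@@H](C(C)(C)C)CC2`: 85 nM
compound 2, `C[C@H](c1ccc(C(=O)NCCC(=O)O)cc1)N1C(=O)C(c2cccc(C3CC3)c2)=N[C@]12CC[C@@H](C(C)(C)C)CC2`: 56 nM

Within the data shown here, in an assay on CHO cells for displacement of a labelled ligand from Glucagon receptor (Homo sapiens), read by scintillation counting, with a stated time of 60 min (on this read-out lower numbers stand for stronger inhibition and higher numbers for weaker inhibition), compound 2 gives 56 nM, the lowest of the two numbers; its only neighbour is compound 1, and the gap lies within the scatter: a 1.5-fold lower number from compound 1 to compound 2 (0.18 log units; within the scatter). On these two numbers compound 2 is not separable from compound 1.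

Compound 3, `C[C@H](c1ccc(C(=O)NCCC(=O)O)cc1)N1C(=O)C(c2cccc(F)c2)=N[C@]12CC[C@@H](C(C)(C)C)CC2`, is not yet measured. Relative to compound 2 the change is fluoro in place of cyclopropyl on an aromatic carbon, that is 3-cyclopropylphenyl to 3-fluorophenyl. Among the measured compounds shown here, the one measured step that bears on it runs in the opposite sense, fluoro giving way to cyclopropyl on the same aryl ring, a 1.5-fold lower number from compound 1 to compound 2 (0.18 log units; within the scatter), and stayed within the scatter; in compound 1 the fluoro stood on 4-fluorophenyl, so the comparison is loose. Neither number points to a step beyond the scatter in either direction. Compound 3 is therefore expected to give about 80 nM in this assay, with a range of 35 nM to 180 nM. The expected step is a 1.4-fold higher number from compound 2 to compound 3 (0.15 log units; within the scatter), no more than the scatter.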

Compound 3, half-maximal inhibitory concentration: 490 nM
Compound 3: middle estimate off by 6.1-fold (0.79 log units), on the low side, and the stated range ends below it.
By their numbers in this assay, from the lowest: compounds 2 and 1 (each within the scatter of the next); then compound 3.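

In this assay the substituent on this aryl ring turns out to matter: fluoro in place of cyclopropyl on an aromatic carbon, meta to a large group, gives an 8.8-fold higher number from compound 2 to compound 3 (0.94 log units; beyond the scatter), whereas the earlier pair showed no step beyond the scatter. The location of the fluoro matters as well, since 3-fluorophenyl in place of 4-fluorophenyl gives a 5.8-fold higher number from compound 1 to compound 3 (0.76 log units; beyond the scatter), so 3-fluorophenyl falls behind both 4-fluorophenyl and 3-cyclopropylphenyl, two groups that remain within the scatter of each other. Nothing measured here accounts for either step.

The compounds shown leave open which feature of the cyclopropyl group carries the difference from fluoro, and a methyl, isopropyl or methoxy group at the same aromatic carbon would show whether other carbon or oxygen substituents track with cyclopropyl or with fluoro. They also leave open how 4-cyclopropylphenyl or unsubstituted phenyl would compare, which would separate the identity of the substituent from its location on the ring.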